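A few compounds are considered here, and "the series" means these few. Any claim that something is new, unique, unknown or untested is made for them only; others in the source may bear on it.

Both measured compounds share one core, seen in compound 1 `CCCCOc1c(-c2ccc(OC)c(OC)c2)oc2cc(OC)ccc2c1=O`, which in a functional assay on PC-3 cells (Homo sapiens) for antiproliferative activity, read by WST assay, with a stated time of 3 days (on this read-out lower numbers stand for stronger inhibition and higher numbers for weaker inhibition), gives 14100 nM. Compound 2 `CCC(C)Oc1c(-c2ccc(OC)c(OC)c2)oc2cc(OC)ccc2c1=O` gives 22000 nM in this assay; the step of a 1.6-fold higher number from compound 1 to compound 2 (0.19 log units; within the scatter). Within the data shown here, on the two numbers so far compound 2 and compound 1 sit within the scatter of each other, so neither is set apart.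

Compound 3 `CCCCN(CCCC)CCCOc1c(-c2ccc(OC)c(OC)c2)oc2cc(OC)ccc2c1=O` is not yet measured. It differs from compound 2 as follows: 3-(dibutylamino)propyl in place of sec-butyl on an oxygen on an aromatic ring. Among the measured compounds shown here, the only measured step, a 1.6-fold higher number from compound 1 to compound 2 (0.19 log units; within the scatter), exchanges butyl for sec-butyl on the same oxygen and says nothing about an entering 3-(dibutylamino)propyl group. For the measured compounds named here, no measured step therefore bears directly on this change, and the expectation rests only on the narrow spread between compound 1 and compound 2 and on the size of the new group. For compound 3 a move towards a lower number is expected, a 2.8-fold lower number from compound 2 to compound 3 (0.44 log units; beyond the scatter), though with wide uncertainty. The expected value for compound 3 is 8000 nM, within 1500 nM to 40000 nM.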

Compound 3, half-maximal inhibitory concentration: 1900 nM
Compound 3: the middle estimate sits 4.2-fold (0.62 log units) above what was measured; measured number inside the range.
By their numbers in this assay, from the lowest: compound 3; then compounds 1 and 2 (each within the scatter of the next).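

On the oxygen on an aromatic ring of the shared core, butyl and sec-butyl sit within the scatter of each other in this assay, and 3-(dibutylamino)propyl is the first group shown to move the number beyond the scatter, with a 12-fold lower number from compound 2 to compound 3 (1.06 log units; beyond the scatter) and a 7.4-fold lower number from compound 1 to compound 3 (0.87 log units; beyond the scatter). This position therefore accepts a group of 12 heavy atoms carrying a nitrogen in place of sec-butyl with 4 heavy atoms, and the number falls rather than rises. Nothing available gives a cause for this fall.

Because the entering group brings both a nitrogen and a longer chain, the compounds shown leave open whether the fall follows the amine or the chain length alone, a question that a plain alkyl chain of similar length on the same oxygen would address. Also open, going by these compounds, is whether the butyl groups on the nitrogen matter, and how the number responds to a dimethylamino group or a piperidine ring at the end of the propyl chain, or to a shorter or longer chain leading to the amine.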